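This account rests on a few compounds, and the source may have more. Where it says the series, first, only, none or still open, it means among the compounds named here.

Series notes, aryl amidoxime sulfonamides

Three compounds of this series carry measurements in an assay for inhibition of Indoleamine 2,3-dioxygenase 1 (Homo sapiens), read by fluorescence, with a stated time of 24 h; on this read-out lower numbers stand for stronger inhibition and higher numbers for weaker inhibition. Compound 1 `NS(=O)(=O)CC(=O)NCCSc1nonc1/C(=N/O)Nc1cccc(Cl)c1` gives 10 nM in this assay. Compound 2 `C[C@H](CSc1nonc1/C(=N/O)Nc1ccc(F)c(Br)c1)NC(=O)CS(N)(=O)=O` gives 12 nM, which lies within the scatter of the number for compound 1. Compound 3 `NS(=O)(=O)NCCSc1nonc1/C(=N/O)Nc1ccc(F)c(Br)c1` gives 2.8 nM, and the gap between compound 3 and compound 1 is beyond the scatter. On these three numbers compound 1 stands second highest, close to compound 2 and furthest from compound 3. Within the data shown here, compound 2 and compound 3 differ from compound 1 in more than one place, so no single step between measured compounds is available.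

Compound 4 `NS(=O)(=O)CC(=O)NCCSc1nonc1/C(=N/O)Nc1cccc(Br)c1` awaits measurement in this assay. It differs from compound 1 in one place: bromo in place of chloro on an aromatic carbon. Among the measured compounds shown here, nothing among the measured compounds isolates this exchange, so no measured step guides it; the expectation is a step of no size beyond the scatter, in either direction. Compound 4 is therefore expected to give 8 nM in this assay, with a range from 3.5 nM to 20 nM, the estimated step being a 1.3-fold lower number from compound 1 to compound 4 (0.10 log units; within the scatter).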

Compound 4, half-maximal inhibitory concentration: 8.1 nM
Compound 4: middle estimate off by 1.0-fold (0.01 log units), on the low side; low and high end bracket the measured number.
By their numbers in this assay, from the lowest: compound 3; then compounds 4, 1 and 2 (each within the scatter of the next).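

Going from 3-chlorophenyl to 3-bromophenyl on an otherwise unchanged structure gives, in this assay, a 1.2-fold lower number from compound 1 to compound 4 (0.09 log units; within the scatter) and so does not separate the two halogens at this aromatic carbon. Among these compounds, this is the first comparison that isolates a single place, which the earlier compounds, all differing in more than one place, could not provide. At least with this sulfonamide side chain, either halogen is accepted here without a step beyond the scatter, and no supporting data bear on why the two numbers lie so close.

The compounds shown leave open how a nitrile, a methoxy group or plain hydrogen at this carbon would read, and thus whether anything other than a halogen is accepted. They also leave open whether the same exchange reads alike on a sulfamide or other side chain.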